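A few compounds are considered here, and "the series" means these few. Any claim that something is new, unique, unknown or untested is made for them only; others in the source may bear on it.

Two measured compounds share one core. Compound 1 `COc1ccn([C@@H]2O[C@H](COP(=O)(O)OP(=O)(O)OP(=O)(O)O)[C@@H](O)[C@H]2O)c(=O)n1` gives 15500 nM in a functional assay on cells for agonist activity at P2Y purinoceptor 2 (Homo sapiens), read by inositol phosphate accumulation, with a stated time of 90 min; on this read-out lower numbers stand for an effect already at smaller amounts and higher numbers for an effect only at larger amounts of compound. Compound 2 `CCCCCCOc1ccn([C@@H]2O[C@H](COP(=O)(O)OP(=O)(O)OP(=O)(O)O)[C@@H](O)[C@H]2O)c(=O)n1` gives 489000 nM in this assay, the highest of the two numbers, and its nearest neighbour is compound 1, which lies a 32-fold higher number from compound 1 to compound 2 (1.50 log units; beyond the scatter) apart, a step made by pentyl in place of hydrogen on a saturated chain carbon bound to an oxygen on an aromatic ring.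

Compound 3 `CCCCCCSc1ccn([C@@H]2O[C@H](COP(=O)(O)OP(=O)(O)OP(=O)(O)O)[C@@H](O)[C@H]2O)c(=O)n1` is not yet measured. Its change from compound 2 is hexylsulfanyl in place of hexyloxy on an aromatic carbon. Within the data shown here, no measured step touches the exchange of oxygen for sulfur at this position; the one step seen concerns only the length of the chain. With nothing to lean on, the expected change from compound 2 to compound 3 is none beyond the scatter, no change at the digits printed from compound 2 to compound 3 (within the scatter), with a wide range. Compound 3 is therefore estimated at 489000 nM, between 100000 nM and 2400000 nM.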

Compound 3, half-maximal effective concentration: 840 nM
Beside the measured number, compound 3's estimate is 580-fold (2.77 log units) above it; measured number below the stated range.
By their numbers in this assay, from the lowest: compound 3; then compound 1; then compound 2.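

The atom linking the chain to the core proves decisive at this position: in this assay, hexylsulfanyl in place of hexyloxy gives a 580-fold lower number from compound 2 to compound 3 (2.77 log units; beyond the scatter) (a step far larger than the one seen on lengthening the chain). The long chain is thus not unfavourable at this position in itself, since compound 3 also improves on the small methoxy group of compound 1 (an 18-fold lower number from compound 1 to compound 3 (1.27 log units; beyond the scatter)), the reverse of the direction of a 32-fold higher number from compound 1 to compound 2 (1.50 log units; beyond the scatter) (the step within the oxygen-linked pair). Nothing given here accounts for this difference between oxygen and sulfur.

The compounds shown leave open how the sulfur-linked chain depends on its length, as neither methylsulfanyl nor a longer chain on sulfur appears among them. They also leave open whether a nitrogen link, as in hexylamino, would behave like the oxygen or the sulfur link.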